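Methoxyphenyl positional change on the shared core

The source may report more compounds than this note shows. Statements on the series, on what has been measured and on what is new or still open speak of the compounds shown alone.

Measured compounds:
compound 1 `c1ccc(Nc2cncc3nc(-c4ccc(N5CCCCC5)cc4)cnc23)cc1` — > 100000 nM
compound 2 `CCNC(=O)Nc1nccc2nc(-c3ccccc3)cnc12` — > 100000 nM
compound 3 `COc1ccccc1Nc1nccc2nc(-c3ccccc3)cnc12` — > 100000 nM

In an assay on Sf21 cells for inhibition of high affinity nerve growth factor receptor (Homo sapiens), read by AlphaScreen, with a stated time of 1 h (on this read-out lower numbers stand for stronger inhibition and higher numbers for weaker inhibition), compound 1 gives no number, only a limit of the assay, > 100000 nM. In this assay compound 2 likewise stops at a limit, > 100000 nM. In this assay compound 3 also reaches only a limit, > 100000 nM. The step that the two limits leave unreadable from compound 2 to compound 3 therefore cannot be read, as both ends are limits. Compound 3 thus stands where every value in the series stands, at the limit (the limit of > 100000 nM in this assay, at which 3 of the 3 values shown sit), with no value in the series resolved to a number.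

Compound 4 `COc1cccc(Nc2nccc3nc(-c4ccccc4)cnc23)c1` is yet to be measured. It differs from compound 3 by 3-methoxyphenyl in place of 2-methoxyphenyl on a nitrogen on an aromatic ring. Within the data shown here, no measured step bears on this change in a readable way: the only step, a step that the two limits leave unreadable from compound 2 to compound 3, has no readable size, and no positional isomer pair has been measured. Nothing in the series points to a resolvable gain from moving the methoxy group.

Compound 4 is therefore expected to sit at or near the limit, with an estimate of 100000 nM and a range from 20000 nM to 300000 nM. The step of a number no higher from compound 3 to compound 4 (the limit leaves the size open) is expected to show nothing beyond the scatter, with a high chance that compound 4 again returns only a limit.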

Compound 4, half-maximal inhibitory concentration: > 100000 nM
Compound 4: no number, only a limit; the forecaster's own chance of this, stated with the estimate: 80%; the middle value sits exactly at the limit.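

In this assay compound 4 gives > 100000 nM, a limit and not a number. The steps from compound 2 and compound 3 to compound 4 therefore cannot be read, as both ends of each are limits. The compounds shown leave open whether 2-methoxyphenyl, 3-methoxyphenyl or ethylcarbamoyl on the nitrogen differ in inhibition at all, with every value at one ceiling: the limit of > 100000 nM in this assay, at which 4 of the 4 values shown sit.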